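A few compounds are considered here, and "the series" means these few. Any claim that something is new, unique, unknown or untested is made for them only; others in the source may bear on it.

Compound 1, `O=C(/C=C/CCCCCCc1ccccc1)N1CCCCCC1`: in a functional assay on PANC-1 cells (Homo sapiens) for cytotoxicity, read by WST assay, with a stated time of 24 h (on this read-out higher numbers stand for weaker inhibition and lower numbers for stronger inhibition), compound 1 gives > 100000 nM, which is a limit of the assay rather than a number.
Compound 2, `O=C(CCCCCCCCc1ccccc1)N1CCCCC1`: in this assay compound 2 gives > 100000 nM, again a limit and not a number.
Compound 3, `O=C(CCCCCCCc1ccccc1)N1CCCCC1`: in this assay compound 3 gives > 100000 nM, also a limit.

Compound 2 therefore stands at the ceiling of the measured range, with no number of its own; it shares this position with both other compounds, since (the limit of > 100000 nM in this assay, at which 3 of the 3 values shown sit). Going by the values given here, the only single-site step among the measured compounds is a step that the two limits leave unreadable from compound 2 to compound 3. Both ends of it sit at a limit, and its size cannot be read.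

The unmeasured compound 4, `O=C(CCCCCCCCc1ccccc1Cl)N1CCCCC1`, differs from compound 2 by chloro in place of hydrogen on an aromatic carbon. No measured step touches a chloro group or a change on the aromatic ring, so nothing among the shown data bears directly on this change, and no step of readable size exists at all.

With every neighbour at the same limit, compound 4 is expected to remain there too, which would mean a step of a number no higher from compound 2 to compound 4 (the limit leaves the size open) in this assay. Compound 4 is accordingly estimated at 100000 nM, within a range from 30000 nM to 300000 nM.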

Compound 4, half-maximal inhibitory concentration: > 100000 nM
Compound 4 was reported as a limit; the forecaster's own chance of this, stated with the estimate: 80%; the middle value sits exactly at the limit.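

In this assay compound 4 gives > 100000 nM, which is a limit and not a number. As compound 2 also stands at a limit, no new step can be read between the two. The compounds shown leave open how far any of them lies past the limit, and which change, if any, would yield a readable value: the limit of > 100000 nM in this assay, at which 4 of the 4 values shown sit.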